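The source may report more compounds than this note shows. Statements on the series, on what has been measured and on what is new or still open speak of the compounds shown alone.

Among the measured compounds shown here, in a functional assay on MCF7 cells (Homo sapiens) for antiproliferative activity, read by CellTiter-Glo, with a stated time of 5 days (on this read-out lower numbers stand for stronger inhibition and higher numbers for weaker inhibition), compound 1 (`CC/C(=C(/c1ccc(/C=C/C(=O)O)cc1)c1ccc(-c2cncs2)cc1)c1ccccc1`) gives 31 nM, the lowest number of the three measured so far. Compound 2 (`CC/C(=C(/c1ccc(/C=C/C(=O)O)cc1)c1ccc(-c2cnn(C)c2)cc1)c1ccccc1`) gives 80 nM, and compound 3 (`CC/C(=C(/c1ccc(/C=C/C(=O)O)cc1)c1ccc(N2CCN(C)CC2)cc1)c1ccccc1`) gives 220 nM.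

Compound 4 (`O=C(O)/C=C/c1ccc(/C(=C(\c2ccccc2)C2CCC2)c2ccc(-c3cncs3)cc2)cc1`) keeps the 1,3-thiazol-5-yl group of compound 1 and changes a different part of the molecule: cyclobutyl in place of ethyl on a double-bonded chain carbon bound to an aromatic carbon and a double-bonded chain carbon. For the measured compounds named here, none of the measured compounds varies the ethyl group, so no measurement bears directly on this change. Going by the values given here, the only guide is the size of the steps made elsewhere, on an aromatic carbon. Those steps are modest: a 2.6-fold higher number from compound 1 to compound 2 (0.41 log units; beyond the scatter), a 7.1-fold higher number from compound 1 to compound 3 (0.85 log units; beyond the scatter) and a 2.8-fold higher number from compound 2 to compound 3 (0.44 log units; beyond the scatter). They say nothing about direction at the ethyl position, so a clear gain or loss cannot be predicted. No step beyond the scatter is expected, with a slightly weaker result as the best guess, and the estimated change is a 1.3-fold higher number from compound 1 to compound 4 (0.11 log units; within the scatter). The expected value for compound 4 is 40 nM, within an estimated range of 12 nM to 130 nM.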

Compound 4, half-maximal inhibitory concentration: 9.2 nM
Beside the measured number, compound 4's estimate is 4.3-fold (0.64 log units) above it; measured number below the stated range.
By their numbers in this assay, from the lowest: compound 4; then compound 1; then compound 2; then compound 3.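

Among the compounds shown here, the ethyl position, which no earlier compound varied, proves sensitive in this assay: cyclobutyl in place of ethyl gives a 3.4-fold lower number from compound 1 to compound 4 (0.53 log units; beyond the scatter). This place on the double-bonded chain carbon therefore accepts a group with more heavy atoms and a four-membered ring, and the change goes toward stronger inhibition. No measurement shown explains this shift.

The compounds shown cannot separate the effect of the ring from that of the added carbon atoms, a question that an open butyl chain or a cyclopropyl or cyclopentyl ring at this place would address. They also leave open whether cyclobutyl would lower the number in the same way alongside the 1-methyl-1H-pyrazol-4-yl group of compound 2 or the 4-methylpiperazin-1-yl group of compound 3.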